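Series notes: pyridin-3-yl replacing benzyl on the ring nitrogen

The source may hold more compounds than are shown below. What is called first, only, known or untested is meant among the compounds shown, and "the series" means these compounds.

Measured so far:
compound 1, `COc1ccc(N2CCN(C(=S)SCc3ccc(C(=O)Nc4ccccc4N)cc3)CC2)cc1`: 25.3%
compound 2, `Nc1ccccc1NC(=O)c1ccc(CSC(=S)N2CCN(Cc3ccccc3)CC2)cc1`: 18.1%

In a functional assay on MGC-803 cells (Homo sapiens) for antiproliferative activity, read by CCK-8 assay, with a stated time of 72 h, tested at 2 uM (on this read-out higher numbers stand for a stronger effect at the one concentration tested and lower numbers for a weaker effect), compound 1 gives 25.3% and compound 2 gives 18.1%. For the measured compounds named here, compound 2 stands within the scatter of compound 1; the only measured step, a number 7.2 percentage points lower from compound 1 to compound 2 (within the scatter), does not reach beyond the scatter. Compound 3, `Nc1ccccc1NC(=O)c1ccc(CSC(=S)N2CCN(c3cccnc3)CC2)cc1`, carries the change (pyridin-3-yl in place of benzyl on an amine nitrogen in a ring). Going by the values given here, no measured step brings pyridin-3-yl onto an amine nitrogen in a ring; the nearest comparison is the exchange of groups on that same nitrogen from compound 1 to compound 2, which stayed within the scatter. A step no larger than the scatter is therefore expected, a number 3.9 percentage points higher from compound 2 to compound 3 (within the scatter). For compound 3 the estimate is 22%, with a range of 8% to 38%.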

Compound 3, a percentage reported as inhibition, at one concentration (the size of the read-out at that concentration, not a potency): 27.6%
The estimate for compound 3 lay 5.6 percentage points below the measured number; the measured number falls inside the stated range.
By their numbers in this assay, from the lowest: compounds 2, 1 and 3 (each within the scatter of the next).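

In this assay, pyridin-3-yl on the amine nitrogen in the ring gives a number 9.5 percentage points higher from compound 2 to compound 3 (within the scatter) and a number 2.3 percentage points higher from compound 1 to compound 3 (within the scatter), so the hetero atom and hydrogen-bond acceptor it brings do not separate it from either earlier group. Benzyl, 4-methoxyphenyl and pyridin-3-yl on this nitrogen all remain within the scatter of one another. No evidence here bears on this result.

Still open, from the compounds shown here alone, is whether a carboxylic acid or an amine on the aromatic ring, or a longer chain on this nitrogen, would give a step beyond the scatter.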